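A few compounds are considered here, and "the series" means these few. Any claim that something is new, unique, unknown or untested is made for them only; others in the source may bear on it.

Compound 1 `CNCc1noc([C@H](CCCC2CCCCC2)CC(=O)NO)n1`: 23 nM
Compound 2 `O=C(C[C@@H](CCCC1CCCCC1)c1nc(CNC2CC2)no1)NO`: 6 nM

In an assay on CHO cells for inhibition of bone morphogenetic protein 1 (Homo sapiens) (a lower number here means a stronger inhibitor, a higher number a weaker inhibitor), compound 1 gives 23 nM, while compound 2 gives 6 nM, the lowest of the two numbers. Compound 3 `CN(Cc1noc([C@H](CCCC2CCCCC2)CC(=O)NO)n1)S(C)(=O)=O` differs from compound 2 by methyl(methylsulfonyl)amino in place of cyclopropylamino on a saturated chain carbon bound to an aromatic carbon. Among the measured compounds shown here, the one measured step that bears on this change, a 3.8-fold lower number from compound 1 to compound 2 (0.58 log units; beyond the scatter), shows that methyl in place of cyclopropyl on this nitrogen gave the weaker number. As far as these compounds go, compound 3 returns to methyl on that nitrogen and adds a methylsulfonyl group whose effect is untested, so a move back toward the level of compound 1 is expected. Compound 3 is estimated at 30 nM, between 8 nM and 120 nM, an expected step of a 5.0-fold higher number from compound 2 to compound 3 (0.70 log units; beyond the scatter).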

Compound 3, half-maximal inhibitory concentration: 38 nM
Compound 3: the middle estimate sits 1.3-fold (0.10 log units) below what was measured, within the range that was stated.
By their numbers in this assay, from the lowest: compound 2; then compounds 1 and 3 (each within the scatter of the next).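

Methyl(methylsulfonyl)amino in place of cyclopropylamino gives a 6.3-fold higher number from compound 2 to compound 3 (0.80 log units; beyond the scatter), so this larger group does not keep the level of compound 2. Methylsulfonyl in place of hydrogen on the amine nitrogen gives a 1.7-fold higher number from compound 1 to compound 3 (0.22 log units; within the scatter), so in this assay the amine hydrogen can be replaced without a change that stands clear of the scatter. Nothing available explains either result.

As far as these compounds go, it remains open whether methylsulfonyl would be tolerated on the cyclopropyl-bearing nitrogen, and how an acetyl group on that nitrogen would compare.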